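Substituent change on the benzyl ether in a HeLa series

The source may report more compounds than this note shows. Statements on the series, on what has been measured and on what is new or still open speak of the compounds shown alone.

Compound 1 `COc1cc(CNCc2ccncc2)ccc1OCc1ccc(C(F)(F)F)cc1` in a functional assay on HeLa cells (Homo sapiens) for inhibition, with a stated time of 72 h (a higher number here means that more compound is needed for the effect, a lower number that less compound is needed), gives 2400 nM.
Compound 2 `COc1cc(CNCc2ccncc2)ccc1OCc1ccc([N+](=O)[O-])cc1` in this assay gives 440 nM.

Among the measured compounds shown here, compound 2 stands at the lowest of the two numbers; the single measured step, a 5.5-fold lower number from compound 1 to compound 2 (0.74 log units; beyond the scatter), separates it from compound 1 by more than the scatter. Compound 3 `COc1cc(CNCc2ccncc2)ccc1OCc1ccc(Cl)nc1` differs from compound 2 by 6-chloropyridin-3-yl in place of 4-nitrophenyl on a saturated chain carbon bound to an oxygen on an aromatic ring.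

For the measured compounds named here, the one measured step exchanged only the group on that ring and moved the number modestly. Going by the values given here, the present change replaces the whole ring together with its group, so no measured step speaks to it directly; the measured step shows only that this part of the molecule is not indifferent to change. Compound 2 already holds the lowest number in the set, so a move away from it in this assay is more likely to be upward than downward, and a step of about a 2.3-fold higher number from compound 2 to compound 3 (0.36 log units; beyond the scatter) is expected, with wide uncertainty. For compound 3 the expected value in this assay is 1000 nM, with a range from 300 nM to 3500 nM.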

Compound 3, half-maximal effective concentration: 400 nM
Compound 3: the middle estimate sits 2.5-fold (0.40 log units) above what was measured, and the stated range covers the measured number.
By their numbers in this assay, from the lowest: compounds 3 and 2 (each within the scatter of the next); then compound 1.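

In this assay, the exchange of the whole group on the saturated chain carbon is a step within the scatter (a 1.1-fold lower number from compound 2 to compound 3 (0.04 log units; within the scatter)), so compound 2 and compound 3 cannot be ordered. The earlier step changed only the group on a retained ring of carbon only, whereas this one shows that neither the nitro group nor that all-carbon aromatic ring is required to keep the number at this level: 6-chloropyridin-3-yl, with one hetero atom in the ring, serves equally well in these two compounds. No measurement shown here explains this match between two different groups.

The compounds shown leave open whether the ring nitrogen and the chlorine matter separately, and a 4-chlorophenyl group and an unsubstituted pyridin-3-yl group would be the direct comparisons for that question. On these data alone, it also remains open how far the position tolerates departures from a six-membered aromatic ring, for example a saturated piperidine ring or a plain alkyl chain in place of the ring.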